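Replacing the propanoyl group on the shared core

This account rests on a few compounds, and the source may have more. Where it says the series, first, only, none or still open, it means among the compounds named here.

Going by the values given here, compound 1 `CCC(=O)c1ccc2c(c1)C(n1ccccc1=O)=CC(C)(C)O2` gives 5.85 in a functional assay (trachea) with Rattus norvegicus as the target (a lower number here means a less potent compound, a higher number a more potent compound, by a factor of ten per unit of this negative logarithm), and stands second highest of the three numbers so far. Its nearest neighbour is compound 2 `COc1ccc(C(=O)c2ccc3c(c2)C(n2ccccc2=O)=CC(C)(C)O3)cc1` with 5.72, the step being a number 0.13 log units lower from compound 1 to compound 2 (within the scatter); its furthest is compound 3 `CC1(C)C=C(n2ccccc2=O)c2cc(C(=O)c3c(F)cccc3F)ccc2O1` with 5.99, the step being a number 0.14 log units higher from compound 1 to compound 3 (within the scatter). Between compound 2 and compound 3 the step is a number 0.27 log units higher from compound 2 to compound 3 (within the scatter). Compound 4 `CC1(C)C=C(n2ccccc2=O)c2cc(C(=N)NO)ccc2O1` differs from compound 1 as follows: a group of 4 heavy atoms (1 carbon, 2 nitrogen, 1 oxygen; no ring) in place of a group of 4 heavy atoms (3 carbon, 1 oxygen; no ring), on an aromatic carbon. Among the compounds with values here, none of the measured steps touches the carbonyl itself; all three only exchange the group on its carbonyl carbon and stay within the scatter. Within the data shown here, no measured step therefore bears directly on this change, and a modest lowering is expected as a number 0.35 log units lower from compound 1 to compound 4 (beyond the scatter), with wide uncertainty. For compound 4 in this assay the estimate is 5.5, between 4.8 and 6.2.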

Compound 4, logarithm of the reciprocal of the active concentration, log(1/C): 5.51
Compound 4: middle estimate off by 0.01 log units, on the low side; the measured number falls inside the stated range.
By their numbers in this assay, from the lowest: compounds 4, 2, 1 and 3 (each within the scatter of the next, the first and the last beyond it).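

In this assay, going by these compounds alone, the step of a number 0.34 log units lower from compound 1 to compound 4 (beyond the scatter) is the first at this aromatic carbon to lie beyond the scatter. The earlier steps shown here only exchanged the group on the carbonyl carbon, whereas this change removes the carbonyl itself. Nothing on hand accounts for the size or direction of this step.

The compounds shown do not separate the loss of the carbonyl from the effect of the entering group as a whole. A carboxylic acid or a primary amine on this aromatic carbon would give further points of comparison with the propanoyl group.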